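Shortening an Aryl Ether Chain: Ethoxy to Methoxy

This account rests on a few compounds, and the source may have more. Where it says the series, first, only, none or still open, it means among the compounds named here.

Three compounds sharing one core were tested in a functional assay on A549 cells (Homo sapiens) for cytotoxicity, with a stated time of 48 h; on this read-out higher numbers stand for weaker inhibition and lower numbers for stronger inhibition. Compound 1 `CCOc1ccc2oc(/C=C/[S+](C)[O-])cc(=O)c2c1` gives 1500 nM in this assay; compound 2 `CC(=O)Oc1ccc2oc(/C=C/[S+](C)[O-])cc(=O)c2c1` gives 4100 nM; compound 3 `Cc1ccc2oc(/C=C/[S+](C)[O-])cc(=O)c2c1` gives 1700 nM. Compound 1 holds the lowest of the three numbers, though its gap to compound 3 lies within the scatter, so the two cannot be ordered; only compound 2 stands apart, with a 2.7-fold higher number from compound 1 to compound 2 (0.44 log units; beyond the scatter).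

Compound 4 `COc1ccc2oc(/C=C/[S+](C)[O-])cc(=O)c2c1` has not been measured. It differs from compound 1 in one place: hydrogen in place of methyl on a saturated chain carbon bound to an oxygen on an aromatic ring. Within the data shown here, no measured pair shows exactly this change. The nearest reference is the replacement of the whole ethoxy group by methyl, which gave a 1.1-fold higher number from compound 1 to compound 3 (0.05 log units; within the scatter), and the swap to acetoxy gave a 2.4-fold lower number from compound 2 to compound 3 (0.38 log units; beyond the scatter) back. Since removing the ethoxy altogether barely moved the number, trimming the chain by one carbon is expected to move it even less.

Compound 4 is therefore expected to give 1600 nM in this assay, within 800 nM to 3200 nM, an expected step of a 1.1-fold higher number from compound 1 to compound 4 (0.03 log units; within the scatter) that stays within the scatter.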

Compound 4, half-maximal inhibitory concentration: 1600 nM
Compound 4: middle estimate and measured number agree at the digits printed, and the stated range covers the measured number.
By their numbers in this assay, from the lowest: compounds 1, 4 and 3 (each within the scatter of the next); then compound 2.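

In this assay, among these compounds, the step of a 1.1-fold higher number from compound 1 to compound 4 (0.03 log units; within the scatter) is the first direct reading of a change within the saturated chain on this oxygen, and it shows that ethoxy and methoxy cannot be told apart here. Methoxy and methyl on the aromatic carbon also cannot be told apart, with a 1.1-fold lower number from compound 3 to compound 4 (0.03 log units; within the scatter) showing that an oxygen-linked group is not needed to stay level with compound 1. Acetyl on the oxygen remains the only change that stands clear, as a 2.6-fold lower number from compound 2 to compound 4 (0.41 log units; beyond the scatter) confirms against a second reference compound.

The compounds shown leave open whether a longer chain, an amine or a carboxylic acid at this place would stay level with compounds 1, 3 and 4 or part from them. No measurement given here accounts for the separate standing of compound 2.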